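The source may hold more compounds than are shown below. What is called first, only, known or untested is meant among the compounds shown, and "the series" means these compounds.

Working notes on the series. In a functional assay on HOS cells (Homo sapiens) for antiproliferative activity, with a stated time of 72 h (on this read-out higher numbers stand for weaker inhibition and lower numbers for stronger inhibition), compound 1 `OC[C@H]1O[C@@H](n2cnc3c(NCc4ccc(F)cc4)ncnc32)[C@H](O)[C@@H]1O` gives 13200 nM. Compound 2 `Cc1ccc(CNc2ncnc3c2ncn3[C@@H]2O[C@H](CO)[C@@H](O)[C@H]2O)cc1` reaches only the limit of this assay, > 166000 nM. Compound 3 `COc1ccc(CNc2ncnc3c2ncn3[C@@H]2O[C@H](CO)[C@@H](O)[C@H]2O)c(OC)c1` likewise sits at the limit of this assay, > 166000 nM, so its standing is known only as a bound. Among the compounds with values here, two of the three values shown sit at the limit of > 166000 nM in this assay, at which 2 of the 3 values shown sit, and the only numbered value belongs to compound 1. Both steps that start there, an at least 12-fold higher number from compound 1 to compound 2 (1.09 log units; beyond the scatter) and an at least 12-fold higher number from compound 1 to compound 3 (1.09 log units; beyond the scatter), run toward weaker inhibition. The remaining step, a step that the two limits leave unreadable from compound 2 to compound 3, cannot be sized. Compound 4 `Cc1cccc(CNc2ncnc3c2ncn3[C@@H]2O[C@H](CO)[C@@H](O)[C@H]2O)c1O` differs from compound 3 at the same place: 2-hydroxy-3-methylphenyl in place of 2,4-dimethoxyphenyl on a saturated chain carbon bound to a nitrogen on an aromatic ring. Within the data shown here, no measured step tracks a hydroxy group or a methyl in this part of the series, so the step from compound 3 to compound 4 is expected to be an at least 1.3-fold lower number from compound 3 to compound 4 (0.14 log units; that floor lies within the scatter), with a high chance that only another limit is reported. For compound 4 the expected value in this assay is 120000 nM, within 30000 nM to 400000 nM.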

Compound 4, half-maximal inhibitory concentration: > 166000 nM
Compound 4: only a limit was reported; the forecaster's own chance of this, stated with the estimate: 60%; at least 1.3-fold (0.14 log units) between middle value and limit.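

Within the data shown here, the 2-hydroxy-3-methylphenyl group is the first at this place to carry a hydrogen-bond donor, yet it recovers nothing, with an at least 12-fold higher number from compound 1 to compound 4 (1.09 log units; beyond the scatter). In this assay compound 4 gives > 166000 nM, which is a limit of the assay and not a number. The steps among compound 2, compound 3 and compound 4 cannot be read, so these three groups cannot be ranked, and 4-fluorophenyl remains the only group here with a numbered value, now against three different replacements: the limit of > 166000 nM in this assay, at which 3 of the 4 values shown sit.

Going by these compounds, whether a 4-chlorophenyl, an unsubstituted phenyl or a phenyl bearing an amine would also return a numbered value stays open. Also open is whether the fluoro group itself matters, or whether compound 1 is simply the one compound shown that falls inside the range of the assay.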